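A Trifluoromethyl Swap on the Urea of Compound 1

A few compounds are considered here, and "the series" means these few. Any claim that something is new, unique, unknown or untested is made for them only; others in the source may bear on it.

Compound 1 `O=C(Nc1cccc(-n2cc(-c3ccncc3)c(-c3ccc(Cl)c(O)c3)n2)c1)Nc1ccc(Cl)c(Cl)c1` was tested in a functional assay on NCI-H23 cells (Homo sapiens) for inhibition, read by sulforhodamine B assay, with a stated time of 48 h; on this read-out higher numbers stand for lower toxicity in this test and lower numbers for higher toxicity in this test. In this assay compound 1 gives > 32500 nM, which is a limit of the assay rather than a number. Two related compounds share the same core. Compound 2 `COc1cc(-c2nn(-c3cccc(NC(=O)c4ccc(Cl)c(C(F)(F)F)c4)c3)cc2-c2ccncc2)ccc1Cl` also reaches only a limit in this assay, at > 32500 nM. Compound 3 `COc1cc(-c2nn(-c3cccc(NC(=O)c4ccccc4)c3)cc2-c2ccncc2)ccc1Cl` likewise gives only a limit in this assay, at > 100000 nM. The one pairwise step among these, a step that the two limits leave unreadable from compound 2 to compound 3, cannot be read; both of its ends are limits. Compound 1 therefore stands at the lower of the two limits seen, with the limit of > 32500 nM in this assay, at which 2 of the 3 values shown sit, and the limit of > 100000 nM in this assay, at which 1 of the 3 values shown sits, the only marks of where these values sit.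

Compound 4 `O=C(Nc1cccc(-n2cc(-c3ccncc3)c(-c3ccc(Cl)c(O)c3)n2)c1)Nc1cccc(C(F)(F)F)c1` has not yet been measured. It differs from compound 1 in one place: 3-(trifluoromethyl)phenyl in place of 3,4-dichlorophenyl on an amide-type nitrogen. Among the measured compounds shown here, no measured step touches this part of the molecule. From the three values nothing of size or direction can be drawn, beyond the fact that every compound shown reached a limit. The change from compound 1 to compound 4 is therefore expected to be small, a step that the limit leaves unreadable from compound 1 to compound 4. For compound 4 a value of 60000 nM is estimated, within 25000 nM to 150000 nM, most likely again reported only as a limit.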

Compound 4, concentration lethal to 50% of the cells: > 32500 nM
Compound 4 was reported as a limit; the forecaster's own chance of this, stated with the estimate: 85%; the middle value is on the limit's open side.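

Among the compounds shown here, compound 1 and compound 4 are both reported only as limits in this assay, not as numbers, so no step between them can be read. The compounds shown leave open whether 3-(trifluoromethyl)phenyl in place of 3,4-dichlorophenyl changes toxicity to these cells at all, and what true values lie behind the limits.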